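Benzoate ester gives way to fluorobenzyl ether on the core

This account rests on a few compounds, and the source may have more. Where it says the series, first, only, none or still open, it means among the compounds named here.

Compound 1 `C#CCOc1ccc2c(=O)c(-c3cc(OC)c(OC)cc3OC)coc2c1`: in a functional assay on HepG2 cells (Homo sapiens) for antiproliferative activity, read by MTT assay, with a stated time of 24 h (on this read-out higher numbers stand for weaker inhibition and lower numbers for stronger inhibition), compound 1 gives 4950 nM.
Compound 2 `COc1cccc(C(=O)Oc2ccc3c(=O)c(-c4cc(OC)c(OC)cc4OC)coc3c2)c1`: in this assay compound 2 reaches only the assay limit > 10000 nM.

Compound 2 thus stands at the floor of the numbers shown, where (the limit of > 10000 nM in this assay, at which 1 of the 2 values shown sits). Compound 3 `COc1cc(OC)c(-c2coc3cc(OCc4ccc(F)cc4)ccc3c2=O)cc1OC` differs from compound 2 by 4-fluorobenzyl in place of (3-methoxyphenyl)carbonyl on an oxygen on an aromatic ring. Among the compounds with values here, the one measured step, an at least 2.0-fold higher number from compound 1 to compound 2 (0.30 log units; that floor lies within the scatter), ran from propargyl to (3-methoxyphenyl)carbonyl at that same oxygen, and its floor sits within the scatter; returning to a carbon-linked group points back toward compound 1. Compound 3 is therefore expected near 6000 nM, between 2000 nM and 20000 nM, an estimated step of an at least 1.6-fold lower number from compound 2 to compound 3 (0.22 log units; that floor lies within the scatter).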

Compound 3, half-maximal inhibitory concentration: 1000 nM
Compound 3: middle estimate off by 6.0-fold (0.78 log units), on the high side; measured number outside the range, below it.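

At this oxygen, this assay now shows a gain over propargyl, with a 5.0-fold lower number from compound 1 to compound 3 (0.69 log units; beyond the scatter), so a six-membered aromatic ring on this oxygen does not by itself weaken the read-out. The (3-methoxyphenyl)carbonyl and 4-fluorobenzyl groups both hold such a ring, yet exchanging one for the other gives an at least 10-fold lower number from compound 2 to compound 3 (1.00 log units; beyond the scatter), which shows that the group's other features matter here. Compound 2 stands at a limit, so the size of that step is only a floor: the limit of > 10000 nM in this assay, at which 1 of the 3 values shown sits.

The compounds shown leave open what the fluorine contributes, and whether an unsubstituted benzyl group would match 4-fluorobenzyl. On these data alone, how an amine or a longer chain on this oxygen would read also stays open.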